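The source may hold more compounds than are shown below. What is called first, only, known or untested is meant among the compounds shown, and "the series" means these compounds.

Measured in a functional assay on MDA-MB-231 cells (Homo sapiens) for cytotoxicity, read by sulforhodamine B assay, with a stated time of 48 h, tested at 0.001 uM; a higher number here means a weaker effect of the compound at the concentration tested, a lower number a stronger effect:
compound 1 `COc1cc(C)cc(-c2c(-c3ccnc(-c4ccc(N(C)C)cc4)c3)cnn2CC#N)c1` gives 101%
compound 2 `COc1cc(C)cc(-c2nn(CC#N)cc2-c2ccnc(-c3ccc(N(C)C)cc3)c2)c1` gives 97%

Compound 1 stands at the top of these two numbers, yet compound 2 differs from it only within the scatter, so the two are read as alike, with no effect at the concentration tested. Going by the values given here, no step between measured compounds is recorded for this pair, so it carries no information on the change at hand.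

Compound 3 `COc1cc(C)cc(-c2c(-c3ccnc(-c4ccc(C(C)=O)cc4)c3)cnn2CC#N)c1` differs from compound 1 by acetyl in place of dimethylamino on an aromatic carbon. With both measured compounds showing no effect, the step in this assay is expected to be none beyond the scatter. Compound 3 is expected at 99%, in the range 85% to 110%. The step of a number 2 percentage points lower from compound 1 to compound 3 (within the scatter) is thus expected to be flat.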

Compound 3, a percentage reported as activity, at one concentration (the size of the read-out at that concentration, not a potency): 99%
For compound 3 middle estimate and measured number coincide at the digits printed; measured number inside the range.
By their numbers in this assay, from the lowest: compounds 2, 3 and 1 (each within the scatter of the next).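

In this assay, acetyl in place of dimethylamino on an aromatic carbon, para to a large group, gives a number 2 percentage points lower from compound 1 to compound 3 (within the scatter). The 4-(dimethylamino)phenyl and 4-acetylphenyl groups therefore read alike here, and compound 3 shows no effect at the concentration tested, so this position gains no ranking from the change. Open, as far as these compounds go, is whether a carboxylic acid or a primary amine at this position would move the read-out. Also open, from the compounds shown here alone, is how compound 1 and compound 3 compare at other concentrations. No measurement shown here accounts for the flat step.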